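From Compound 2 to Compound 3: One Group Exchanged

This account rests on a few compounds, and the source may have more. Where it says the series, first, only, none or still open, it means among the compounds named here.

Among the compounds with values here, in a functional assay on the whole organism (strain Kunming) with Mus musculus as the target, in the formalin test, with a stated time of 0.5 h (on this read-out higher numbers stand for an effect only at larger amounts of compound and lower numbers for an effect already at smaller amounts), two compounds with a shared core have numbers so far. Compound 1 (`COc1cc(OC)c(OC)cc1/C=C/COC(=O)/C=C/c1cc(OC)c(OC)c(OC)c1OC`) gives 89 umol/kg and compound 2 (`COc1cc(OC)c(OC)cc1/C=C/COC(=O)/C=C/c1ccccc1C(F)(F)F`) gives 291 umol/kg on this read-out. Compound 2 therefore holds the higher of the two numbers, and its gap to compound 1 lies beyond the scatter.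

Compound 3 (`COc1cc(OC)c(OC)cc1/C=C/COC(=O)/C=C/c1ccc(F)cc1`) has yet to be measured. It departs from compound 2 in one place, on a double-bonded chain carbon bound to a double-bonded chain carbon, where 4-fluorophenyl stands in place of 2-(trifluoromethyl)phenyl (4-fluorophenyl in place of 2-(trifluoromethyl)phenyl on a double-bonded chain carbon bound to a double-bonded chain carbon). Within the data shown here, no measured pair shows what this exchange does, so any forecast remains loose. Among the measured compounds shown here, the only guide is that compound 2 at 291 umol/kg sits at the top of the numbers seen, while compound 1 at 89 umol/kg shows that lower numbers occur with this core. In this assay a small fall is therefore expected, estimated as a 1.7-fold lower number from compound 2 to compound 3 (0.23 log units; within the scatter) and not clearly beyond the scatter. For compound 3 the estimated value is 170 umol/kg with an expected range from 70 umol/kg to 400 umol/kg on the same read-out.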

Compound 3, dose for half-maximal effect: 117 umol/kg
Estimate against measurement, compound 3: 1.5-fold (0.16 log units) above; the measured number falls inside the stated range.
By their numbers in this assay, from the lowest: compounds 1 and 3 (each within the scatter of the next); then compound 2.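

In this assay, within the data shown here, the exchange of 2-(trifluoromethyl)phenyl for 4-fluorophenyl on a double-bonded chain carbon bound to a double-bonded chain carbon brings a 2.5-fold lower number from compound 2 to compound 3 (0.40 log units; beyond the scatter) and gives this position its only single-place step so far, a modest one. The number therefore responds to a change at this place alone, with the rest of the shared core left as it is, and the smaller group, with fewer heavy atoms, here goes with an effect at smaller amounts. Nothing measured alongside these numbers accounts for the step.

The exchange alters both the substituent on the phenyl ring and the number of its place, and the compounds shown do not separate these two changes. They also leave open how the number would respond if an unsubstituted phenyl, an amine or a carboxylic acid stood on this double-bonded chain carbon.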